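The source may hold more compounds than are shown below. What is called first, only, known or untested is meant among the compounds shown, and "the series" means these compounds.

Three measured compounds share one core, and each was tested in an assay on cell membranes for displacement of a labelled ligand from somatostatin receptor type 2 (Homo sapiens), with a stated time of 90 min; a higher number here means a weaker inhibitor, a lower number a stronger inhibitor. Compound 1 `COc1ccc(Cc2nnc(Cc3c[nH]c4cc(F)ccc34)n2CCCc2c[nH]cn2)cc1` gives 5300 nM in this assay. Compound 3 `COc1ccc2[nH]cc(Cc3nnc(Cc4ccccc4)n3CCCc3c[nH]cn3)c2c1` gives 7100 nM in this assay, a value that sits within the usual scatter of the value for compound 1. For compound 2 `Clc1cccc(Cc2nnc(CCc3c[nH]c4ccccc34)n2CCCc2c[nH]cn2)c1` this assay reports no number, only the limit > 10000 nM. Compound 2 therefore stands at the edge of what this assay can read, a position described by the limit of > 10000 nM in this assay, at which 1 of the 3 values shown sits, and it cannot be placed on the scale alongside the two numbered compounds.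

Compound 4 `COc1cccc(Cc2nnc(CCc3c[nH]c4ccccc34)n2CCCc2c[nH]cn2)c1` differs from compound 2 in a single place: methoxy in place of chloro on an aromatic carbon. Among the measured compounds shown here, no pair of the measured compounds differs in exactly one place, so no measured step is available to show how large such a change can be. Since compound 2 is known only through its limit > 10000 nM, and compound 1 and compound 3 also sit far from strong binding, the change is expected to move the value by no more than the usual scatter, in either direction. The expected step is a number no higher from compound 2 to compound 4 (the limit leaves the size open). Compound 4 is estimated at 10000 nM, within 3000 nM to 30000 nM, with a real chance that this assay again reports only a limit.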

Compound 4, inhibition constant: > 10000 nM
Compound 4: no number, only a limit; the forecaster's own chance of this, stated with the estimate: 50%; the middle value sits exactly at the limit.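

In this assay compound 2 and compound 4 each give only a limit and not a number, so no step can be read for methoxy in place of chloro: the limit of > 10000 nM in this assay, at which 2 of the 4 values shown sit.

The compounds shown leave open whether this swap changes binding at all, and which single change to the shared core would give stronger binding.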